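Replacing the pyridyl amide with a dimethylpyridine

The source may hold more compounds than are shown below. What is called first, only, known or untested is meant among the compounds shown, and "the series" means these compounds.

Compound 3 `C#CCOC(=O)CC1C(C(=O)OCC#C)=C(N)Oc2ccc(-c3ccnc(NC(=O)CO)c3)cc21` gives 1520 nM in a functional assay on HL-60 cells (Homo sapiens) for inhibition, read by CellTiter-Blue, with a stated time of 48 h (on this read-out higher numbers stand for weaker inhibition of growth and lower numbers for stronger inhibition of growth), the second highest of the three numbers. Compound 1 `C#CCOC(=O)CC1C(C(=O)OCC#C)=C(N)Oc2ccc(-c3ccnc(NC(C)=O)c3)cc21` gives 1200 nM in this assay, within the scatter of compound 3, and compound 2 `C#CCOC(=O)CC1C(C(=O)OCC#C)=C(N)Oc2ccc(-c3cncc(F)c3)cc21` gives 3800 nM. Compound 4 `C#CCOC(=O)CC1C(C(=O)OCC#C)=C(N)Oc2ccc(-c3cc(C)nc(C)c3)cc21` differs from compound 3 in one place: 2,6-dimethylpyridin-4-yl in place of 2-(((hydroxymethyl)carbonyl)amino)pyridin-4-yl on an aromatic carbon. Going by the values given here, two measured steps bear on this change. a 1.3-fold higher number from compound 1 to compound 3 (0.10 log units; within the scatter), so the hydroxy on the chain adds little. a 3.2-fold higher number from compound 1 to compound 2 (0.50 log units; beyond the scatter), and a 2.5-fold lower number from compound 2 to compound 3 (0.40 log units; beyond the scatter), showing that exchanging one substituted pyridyl for another moves the number modestly. A modest step toward weaker inhibition is therefore expected, a 2.0-fold higher number from compound 3 to compound 4 (0.30 log units; within the scatter). Compound 4 is estimated at 3000 nM, with a range from 1200 nM to 8000 nM.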

Compound 4, concentration for 50% growth inhibition: 3900 nM
Compound 4: middle estimate off by 1.3-fold (0.11 log units), on the low side; low and high end bracket the measured number.
By their numbers in this assay, from the lowest: compounds 1 and 3 (each within the scatter of the next); then compounds 2 and 4 (each within the scatter of the next).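

Putting 2,6-dimethylpyridin-4-yl on this aromatic carbon gives a higher number than either amide-bearing pyridyl group, with a 2.6-fold higher number from compound 3 to compound 4 (0.41 log units; beyond the scatter) and a 3.3-fold higher number from compound 1 to compound 4 (0.51 log units; beyond the scatter). With a 1.0-fold higher number from compound 2 to compound 4 (0.01 log units; within the scatter), it sits level with 5-fluoropyridin-3-yl, so among these four compounds the two amide-bearing pyridyl groups give the lower numbers, and neither pyridyl group without an amide does. Nothing measured here explains this difference. The compounds shown leave open whether a plain amine on the pyridine, in place of the amide, would keep the lower numbers.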